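From methyl to dimethylamino in a cytotoxic series

The source may report more compounds than this note shows. Statements on the series, on what has been measured and on what is new or still open speak of the compounds shown alone.

Among the measured compounds shown here, in a functional assay on HCT-15 cells (Homo sapiens) for cytotoxicity, read by MTT assay, with a stated time of 2 days (on this read-out higher numbers stand for weaker inhibition and lower numbers for stronger inhibition), compound 1 (`Cc1ccc2c(=O)[nH]c(-c3ccccc3C)nc2c1`) gives 11900 nM and is the only compound with a measured number so far. Compound 2 (`Cc1cccc(-c2nc3ccc(C)cc3c(=O)[nH]2)c1`) is recorded only as a limit of the assay, > 50000 nM, and not as a number. Compound 3 (`Cc1ccc2c(=O)[nH]c(-c3ccccc3N(C)C)nc2c1`) departs from compound 1 in one place, with dimethylamino in place of methyl on an aromatic carbon, ortho to a large group: dimethylamino in place of methyl on an aromatic carbon. For the measured compounds named here, no measured step bears on this change, so the expectation rests on compound 1 at 11900 nM alone. In this assay a small move toward weaker inhibition is expected, not clearly beyond the usual scatter. The expected change is a 1.7-fold higher number from compound 1 to compound 3 (0.23 log units; within the scatter). For compound 3 the estimate is 20000 nM, with an expected range from 6000 nM to 50000 nM.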

Compound 3, half-maximal inhibitory concentration: 12800 nM
For compound 3 the middle estimate is 1.6-fold (0.19 log units) above the measured one; low and high end bracket the measured number.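

Among the compounds shown here, the step from methyl to dimethylamino is the first measured change at this place: a 1.1-fold higher number from compound 1 to compound 3 (0.03 log units; within the scatter) in this assay. On an aromatic carbon, ortho to a large group, the number therefore does not move beyond the scatter when methyl gives way to dimethylamino, which adds heavy atoms and a hydrogen-bond acceptor. Nothing measured here bears on why the two groups read alike.

From the compounds shown here alone, whether a carboxylic acid, a primary amine or a longer chain such as butyl at this place would move the number beyond the scatter remains open. For the compounds shown here, compound 2, with > 50000 nM, is a limit of the assay and not a number, and it offers no step to read.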